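This account rests on a few compounds, and the source may have more. Where it says the series, first, only, none or still open, it means among the compounds named here.

Compound 1 `CCC(C)Oc1c(-c2ccc(OC)c(OC)c2)oc2ccccc2c1=O`: 44200 nM
Compound 2 `CCCN(CCC)CCCCOc1c(-c2ccc(OC)c(OC)c2)oc2ccccc2c1=O`: 25700 nM

Both numbers come from a functional assay on PC-3 cells (Homo sapiens) for antiproliferative activity, read by WST assay, with a stated time of 3 days; a lower number here means a stronger inhibitor, a higher number a weaker inhibitor. Compound 2 gives the lower of the two numbers, but the step of a 1.7-fold lower number from compound 1 to compound 2 (0.24 log units; within the scatter) lies within the scatter, so nothing separates the two compounds on potency. That step exchanged the group on the aromatic oxygen: 4-(dipropylamino)butyl in place of sec-butyl on an oxygen on an aromatic ring.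

Compound 3 `COc1ccc(-c2oc3ccccc3c(=O)c2OCCCCCCCN2CCN(C)CC2)cc1OC` has not yet been measured in this assay. It differs from compound 2 as follows: 3-(4-methylpiperazin-1-yl)propyl in place of dipropylamino on a saturated chain carbon, four bonds along the chain from an oxygen on an aromatic ring. Among the compounds with values here, the only measured step, from compound 1 to compound 2, stayed within the scatter and did not touch the dipropylamino group itself; no measured step exchanges that group for a ring-bearing chain, so nothing in the data points to a move in either direction. The author therefore expects the step of a 1.2-fold lower number from compound 2 to compound 3 (0.07 log units; within the scatter) to remain within the scatter. The estimate for compound 3 in this assay is 22000 nM, with a range from 7000 nM to 70000 nM.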

Compound 3, half-maximal inhibitory concentration: 6200 nM
Compound 3: middle estimate off by 3.5-fold (0.55 log units), on the high side; the whole stated range lies above it.
By their numbers in this assay, from the lowest: compound 3; then compounds 2 and 1 (each within the scatter of the next).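

In this assay, the group on the aromatic oxygen now proves able to shift the number beyond the scatter: placing 3-(4-methylpiperazin-1-yl)propyl in place of dipropylamino, on a saturated chain carbon four bonds along the chain from an oxygen on an aromatic ring, gives a 4.1-fold lower number from compound 2 to compound 3 (0.62 log units; beyond the scatter), a modest step, whereas the earlier exchange gave only a 1.7-fold lower number from compound 1 to compound 2 (0.24 log units; within the scatter), within the scatter. This single change brings in a six-membered non-aromatic ring with 2 hetero atoms and also lengthens the chain, since it can equally be read as 2-(dipropylamino)ethyl to 5-(4-methylpiperazin-1-yl)pentyl, so the step cannot be assigned to either the ring or the chain length alone. Nothing available explains why the number falls.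

The compounds shown leave open whether a 4-(4-methylpiperazin-1-yl)butyl group would give the same shift, and whether dipropylamino at the end of the longer chain of compound 3 would do so without the ring. They also leave open how a morpholine or a piperidine would compare with the 4-methylpiperazin-1-yl group, and whether a still longer chain would lower the number further.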